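Chloro for methyl on the shared core

The source may report more compounds than this note shows. Statements on the series, on what has been measured and on what is new or still open speak of the compounds shown alone.

Going by the values given here, in an ADME assay on microsomes from liver (Homo sapiens) for metabolic stability, using NADPH, with a stated time of 40 min, tested at 2 uM (a higher number here means that the compound lasts longer, a lower number that the compound disappears faster), compound 1 `Cc1cccc2c(-c3ccc4cccc(F)c4n3)c[nH]c12` gives 0.983 h and compound 2 `Cc1cccc2ccc(-c3c[nH]c4c(C)cccc34)nc12` gives 1.62 h as its half-life, so compound 2 stands within the scatter of the only other number. Compound 3 `Cc1cccc2c(-c3ccc4cccc(Cl)c4n3)c[nH]c12` differs from compound 2 by chloro in place of methyl on an aromatic carbon with chloro in place of methyl on an aromatic carbon. Among the compounds with values here, the only measured step, a 1.6-fold higher number from compound 1 to compound 2 (0.22 log units; within the scatter) with methyl in place of fluoro, lies within the scatter, so no step beyond the scatter is expected in this assay here. The estimated step is a 1.3-fold lower number from compound 2 to compound 3 (0.11 log units; within the scatter) and is expected to stay within the scatter. For compound 3 the half-life is estimated at 1.25 h with an expected span from 0.65 h to 2.3 h as the working range.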

Compound 3, half-life: 1.75 h
Compound 3: the middle estimate sits 1.4-fold (0.15 log units) below what was measured, within the range that was stated.
By their numbers in this assay, from the lowest: compounds 1, 2 and 3 (each within the scatter of the next).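

At this position on the shared core, three groups can now be compared in this assay. Chloro in place of methyl gives a 1.1-fold higher number from compound 2 to compound 3 (0.03 log units; within the scatter), and chloro in place of fluoro gives a 1.8-fold higher number from compound 1 to compound 3 (0.25 log units; within the scatter), so the half-life does not separate fluoro, methyl and chloro on this aromatic carbon. No evidence is available to explain this result.

As far as these compounds go, whether an amine, a carboxylic acid or a methoxy group on the same carbon would shift the half-life beyond the scatter remains open, as do changes elsewhere on the shared core.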